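A few compounds are considered here, and "the series" means these few. Any claim that something is new, unique, unknown or untested is made for them only; others in the source may bear on it.

Compound 2 `CC(=O)N[C@H]1[C@@H](OCCc2ccccc2)O[C@H](CO)[C@@H](O)[C@@H]1O` is one of three compounds on the shared core tested in a functional assay on C6 cells (Rattus norvegicus), read by thymidine incorporation; a lower number here means a stronger inhibitor, a higher number a weaker inhibitor. In this assay compound 2 gives only a limit, > 50 uM. Compound 1 `CC(=O)N[C@H]1[C@@H](OCc2ccccc2)O[C@H](CO)[C@@H](O)[C@@H]1O` likewise gives a limit, > 50 uM. Compound 3 `CC(=O)N[C@H]1[C@@H](OCCCCc2ccccc2)O[C@H](CO)[C@@H](O)[C@@H]1O` also gives a limit, > 50 uM. The steps a step that the two limits leave unreadable from compound 1 to compound 2 and a step that the two limits leave unreadable from compound 2 to compound 3 cannot be sized because of the limit of > 50 uM in this assay, at which 3 of the 3 values shown sit. Compound 4 `C=CCCC(=O)N[C@H]1[C@@H](OCCc2ccccc2)O[C@H](CO)[C@@H](O)[C@@H]1O` differs from compound 2 by allyl in place of hydrogen on a saturated chain carbon bound to a carbonyl carbon. Neither measured step touches the acetamido group, and neither was readable, so no step beyond the scatter is expected in either direction. Compound 4 is expected to give about 100 uM in this assay, within a range of 30 uM to 500 uM. This amounts to an estimated step that the limit leaves unreadable from compound 2 to compound 4.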

Compound 4, concentration for 50% inhibition: > 50 uM
Compound 4: a limit, no number; the forecaster's own chance of this, stated with the estimate: 70%; the middle value lies beyond the limit too.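

No step can be read between compound 2 and compound 4, because both values are limits: the limit of > 50 uM in this assay, at which 4 of the 4 values shown sit.

The compounds shown leave open whether ((but-3-en-1-yl)carbonyl)amino in place of acetamido changes inhibition in this assay at all.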